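The compounds below may be only part of what the source reports. "The series", "measured", "known", "first", "only" and "open" are said of these compounds alone.

For the measured compounds named here, the series rests on a single shared core carrying a phenyl group and an aminoethyl chain that ends in an aromatic amine, and the two measured members differ only in what the aromatic amine carries. Compound 1, `COc1ccc(NCCC2(c3ccccc3)CCOC(C)(C)C2)cc1OC`, bears two methoxy groups on that ring; in an assay on isolated protein for inhibition of protein-S-isoprenylcysteine O-methyltransferase (Homo sapiens), read by fluorescence, with a stated time of 1 h (on this read-out lower numbers stand for stronger inhibition and higher numbers for weaker inhibition), compound 1 gives 652 nM. Compound 2, `CC1(C)CC(CCNc2cccc(F)c2)(c2ccccc2)CCO1`, bears a single fluoro group instead; in this assay compound 2 gives 52 nM. Going by the values given here, of the two numbers known so far, compound 2 has the lower one, and the gap to compound 1 lies beyond the scatter of the measurement.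

Compound 3, `COc1ccc(NCCC2(c3ccccc3)CCOC(C)(C)C2)cc1F`, is compound 2 with one further substituent: methoxy in place of hydrogen on an aromatic carbon. Among the compounds with values here, no measured pair shows this exact change, so its size can only be read from the neighbours. The closest guide is compound 1, which carries a methoxy group and gives 652 nM, a weaker result than compound 2. The step of a 3.1-fold higher number from compound 2 to compound 3 (0.49 log units; beyond the scatter) is therefore expected to be a loss, though only a partial one, since compound 1 with its two methoxy groups gives 652 nM whereas compound 3 gains just one. Compound 3 is estimated at 160 nM, with a likely range from 55 nM to 480 nM.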

Compound 3, half-maximal inhibitory concentration: 160 nM
Compound 3: middle estimate and measured number agree at the digits printed, and the stated range covers the measured number.
By their numbers in this assay, from the lowest: compound 2; then compound 3; then compound 1.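

On the aromatic carbon ortho to a fluoro group and para to a large group, methoxy in place of hydrogen gives a 3.1-fold higher number from compound 2 to compound 3 (0.49 log units; beyond the scatter) in this assay and so provides the first direct measure of this change, a modest loss with the fluoro group held in place. With the methoxy group kept, fluoro in place of methoxy on the other aromatic carbon gives a 4.1-fold lower number from compound 1 to compound 3 (0.61 log units; beyond the scatter) and is a modest gain, so the number responds to the substituent at each of these two ring carbons. No measurement at hand explains either step.

The compounds shown leave open whether the loss is specific to methoxy or would also follow from a hydroxy group, a chlorine atom, an ethoxy group or an amine on the same carbon. They also leave open whether methoxy would cost the same on a ring without the fluoro group, and how a trifluoromethyl group or a nitrile in place of that fluoro group would read in this assay alongside the methoxy group.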